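Oleyl urea series: widening the 2,6-disubstituted aryl group

A few compounds are considered here, and "the series" means these few. Any claim that something is new, unique, unknown or untested is made for them only; others in the source may bear on it.

Measured so far:
compound 1 `CCCCCCCC/C=C\CCCCCCCCNC(=O)Nc1c(C)cccc1C` — 160 nM
compound 2 `CCCCCCCCCCCCCCCCCCOc1c(C)cccc1C` — > 10000 nM
compound 3 `CCCCCCCCCCCCCCCCCC[S+]([O-])c1c(C)cccc1C` — > 10000 nM

For the measured compounds named here, in an assay on microsomes from intestinal mucosa for inhibition of acyl-CoA:cholesterol acyltransferase (Oryctolagus cuniculus) (a lower number here means a stronger inhibitor, a higher number a weaker inhibitor), compound 1 gives 160 nM and is the only compound of the three with a number rather than a limit. Compound 2 reaches only the assay limit, > 10000 nM. Compound 3 likewise reaches only the assay limit, > 10000 nM. Going by the values given here, two of the three results therefore sit at the limit of > 10000 nM in this assay, at which 2 of the 3 values shown sit, and no step between measured compounds can be read from them; compound 1 stands alone as the reference point.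

Compound 4 `CCCCCCCC/C=C\CCCCCCCCNC(=O)Nc1c(CC)cccc1C(C)C` is not yet measured. It differs from compound 1 in one place: 2-ethyl-6-isopropylphenyl in place of 2,6-dimethylphenyl on an amide-type nitrogen. The urea and the long unsaturated chain of compound 1 are kept unchanged.

Among the compounds with values here, no measured step covers such a change, so the expectation rests on compound 1 alone. The step of a 2.7-fold lower number from compound 1 to compound 4 (0.43 log units; beyond the scatter) is expected to be a modest gain, beyond the scatter but not large. For compound 4 the estimate in this assay is 60 nM, with a range from 15 nM to 300 nM.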

Compound 4, half-maximal inhibitory concentration: 37 nM
Estimate against measurement, compound 4: 1.6-fold (0.21 log units) above, within the range that was stated.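

Replacing 2,6-dimethylphenyl with 2-ethyl-6-isopropylphenyl on an amide-type nitrogen gives a 4.3-fold lower number from compound 1 to compound 4 (0.64 log units; beyond the scatter) in this assay, the first step in the series that can be read, and no other step can be read from the compounds shown. This place on the urea therefore accepts a larger carbon-only aryl group, with a modest gain rather than a loss. Nothing measured here accounts for the size of this step.

From the compounds shown here alone, whether the gain belongs to the ethyl group, the isopropyl group or the pair remains open, as does whether a 2,6-diisopropylphenyl group would extend it. Also open, going by these compounds, is how an aryl group carrying a methoxy or a dimethylamino substituent would behave at this place.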